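Taking one methoxy group off compound 1

The compounds below may be only part of what the source reports. "The series", "measured", "known", "first", "only" and "open" are said of these compounds alone.

Compound 1 `COc1cc(C(=O)NOCCCCCC(=O)NO)cc(OC)c1OC` and compound 2 `O=C(CCCCCONC(=O)c1cc(F)cc(F)c1)NO` share the same long chain and differ in the groups on the aromatic ring. In a functional assay on A2780 cells (Homo sapiens) for cytotoxicity, read by MTT assay (on this read-out higher numbers stand for weaker inhibition and lower numbers for stronger inhibition), compound 1 gives 13800 nM and compound 2 gives 13700 nM as its value. The two stand level within the usual scatter, so compound 1 has no real neighbour above or below it.

Compound 3 `COc1cc(OC)cc(C(=O)NOCCCCCC(=O)NO)c1` changes compound 1 in one place (hydrogen in place of methoxy on an aromatic carbon): hydrogen in place of methoxy on an aromatic carbon, ortho to two methoxy groups and para to a large group. Compound 2 has no methoxy group at all, and its 13700 nM still matches compound 1, so little change is expected in this assay from losing one. The estimated 1.2-fold lower number from compound 1 to compound 3 (0.06 log units; within the scatter) stays within the scatter, with no clear direction. Compound 3 is estimated at 12000 nM and expected to fall between 5500 nM and 26000 nM on repeated measurement.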

Compound 3, half-maximal inhibitory concentration: 890 nM
Compound 3: middle estimate off by 13-fold (1.13 log units), on the high side; the measured number lies below the stated range.
By their numbers in this assay, from the lowest: compound 3; then compounds 2 and 1 (each within the scatter of the next).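

In this assay, putting hydrogen in place of the methoxy group that is ortho to two methoxy groups and para to a large group gives a 16-fold lower number from compound 1 to compound 3 (1.19 log units; beyond the scatter). This shows that a change at this one position on the ring can, by itself, move the number by a large amount. Compounds 1 and 2 differ in more than one place, so their level values could not show this, and nothing given here accounts for the size of the step.

As far as these compounds go, it remains open whether the stronger inhibition depends on having hydrogen here or would also appear with another group at this position, such as a hydroxyl group, an amine or a chlorine atom. From the compounds shown here alone, the effect of taking away either of the other two methoxy groups on its own also remains unknown.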